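Bromo in place of fluoro: compound 3 in prospect

A few compounds are considered here, and "the series" means these few. Any claim that something is new, unique, unknown or untested is made for them only; others in the source may bear on it.

In a functional assay (aorta) with Oryctolagus cuniculus as the target (on this read-out higher numbers stand for weaker binding and lower numbers for tighter binding), compound 1 (`CC(=O)c1ccc(OCCCN2CCC(C(c3ccc(F)cc3)c3ccc(F)cc3)CC2)cc1`) gives 2.51 nM and compound 2 (`Fc1ccc(OCCCN2CCC(C(c3ccc(F)cc3)c3ccc(F)cc3)CC2)cc1`) gives 1.26 nM. Going by the values given here, these are the only two numbers, and they lie within the scatter of each other, so compound 2 stands level with compound 1.

Compound 3 (`Fc1ccc(C(c2ccc(F)cc2)C2CCN(CCCOc3ccc(Br)cc3)CC2)cc1`) has bromo in place of fluoro on an aromatic carbon, para to a large group: bromo in place of fluoro on an aromatic carbon. Among the compounds with values here, no measured compound carries bromo. Within the data shown here, the one measured step bearing on this change, fluoro in place of acetyl at the same place, is a 2.0-fold lower number from compound 1 to compound 2 (0.30 log units; within the scatter). That small step is thin evidence, resting on a single pair, yet it gives no ground for a change beyond the scatter in this assay.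

The expected 1.2-fold higher number from compound 2 to compound 3 (0.08 log units; within the scatter) stays within the scatter. Compound 3 is estimated at 1.5 nM, with an expected range of 0.6 nM to 3.8 nM.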

Compound 3, dissociation constant: 1.59 nM
Compound 3: the middle estimate sits 1.1-fold (0.03 log units) below what was measured, and the stated range covers the measured number.
By their numbers in this assay, from the lowest: compounds 2, 3 and 1 (each within the scatter of the next).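

At the aromatic carbon para to a large group, the change from a halogen to a heavier halogen now has its own step: in this assay, bromo in place of fluoro gives a 1.3-fold higher number from compound 2 to compound 3 (0.10 log units; within the scatter). Bromo in place of acetyl gives a 1.6-fold lower number from compound 1 to compound 3 (0.20 log units; within the scatter), so acetyl, fluoro and bromo all lie within the scatter of one another at this place, and no group among the three separates from the others on this read-out. No measurement on these compounds offers an explanation for the closeness of the three numbers.

Still open, going by these compounds, is whether an amine or a carboxylic acid at this place would give a step beyond the scatter. The same question stands for a longer chain on the oxygen of the phenoxy group.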